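A few compounds are considered here, and "the series" means these few. Any claim that something is new, unique, unknown or untested is made for them only; others in the source may bear on it.

Measured compounds:
compound 1 `CC[C@H](C)C(=O)O[C@H]1CCC=C2C=C[C@H](C)[C@H](COC(=O)CCCC(=O)O)C21`: 7100 nM
compound 2 `CC[C@H](C)C(=O)O[C@@H]1CCC=C2C=C[C@@H](C)[C@@H](COC(=O)CCCC(=O)O)[C@@H]21`: 110000 nM
compound 3 `CC[C@H](C)C(=O)O[C@H]1CCC=C2C=C[C@H](C)[C@H](COC(=O)C[C@@H](O)CC(=O)O)[C@H]21`: 630 nM

In an assay on microsomes from liver for inhibition of 3-hydroxy-3-methylglutaryl-coenzyme A reductase (Rattus norvegicus) (on this read-out lower numbers stand for stronger inhibition and higher numbers for weaker inhibition), compound 2 gives 110000 nM, the highest of the three numbers. The step of a 15-fold higher number from compound 1 to compound 2 (1.19 log units; beyond the scatter) is large; the two compounds share every atom and bond and differ only in how their stereocentres are drawn, and the fact that one of compounds 1 and 2 is drawn with a defined configuration and the other without, at the place where they differ is the one fact known about that pair. Compound 3 carries a hydroxy on its side chain, and in this assay compound 3 gives 630 nM; it differs from compound 1 in more than one place, so only the two values themselves can be set side by side. Compound 4 `CC[C@H](C)C(=O)O[C@@H]1CCC=C2C=C[C@@H](C)[C@@H](COC(=O)C[C@H](O)CC(=O)O)[C@@H]21` is compound 2 with hydroxy in place of hydrogen on a saturated chain carbon bound to two saturated chain carbons. Among the measured compounds shown here, no measured step isolates exactly this change; the values of compound 1 and compound 3 point to a lower number when the hydroxy is present. In this assay compound 4 is therefore expected to give 10000 nM, with a range from 3000 nM to 40000 nM. That corresponds to an expected step of an 11-fold lower number from compound 2 to compound 4 (1.04 log units; beyond the scatter).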

Compound 4, half-maximal inhibitory concentration: 25000 nM
Beside the measured number, compound 4's estimate is 2.5-fold (0.40 log units) below it; measured number inside the range.
By their numbers in this assay, from the lowest: compound 3; then compound 1; then compound 4; then compound 2.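

In this assay, the hydroxy on this saturated chain carbon now has a test in one place: a 4.4-fold lower number from compound 2 to compound 4 (0.64 log units; beyond the scatter), a modest step towards stronger inhibition. With the hydroxy present in both compounds, configuration alone gives a much larger step, a 40-fold higher number from compound 3 to compound 4 (1.60 log units; beyond the scatter), and the structures show that nothing else changes: the fact that compounds 3 and 4 differ only in the configuration as drawn

An amine or a methoxy on the same carbon would show whether the step needs the hydroxy itself. Which of the several changed stereocentres carries the large step stays open, as they all change together.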